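A few compounds are considered here, and "the series" means these few. Any claim that something is new, unique, unknown or untested is made for them only; others in the source may bear on it.

Measured so far in an ADME assay on MDCK cells (Canis lupus familiaris) for cytotoxicity, read by resazurin assay, with a stated time of 3.5 h; a higher number here means a weaker inhibitor, a lower number a stronger inhibitor:
Compound 1 `CCCCCCCCCCCC(=O)NC(CCCCN)C(=O)NCCCCCCCCCCCC(=O)NC(CCCCN)C(=O)O` gives > 100000 nM, which is a limit of the assay and not a number.
Compound 2 `CCCCCCCCCCCC(=O)NC(CCCCN)C(=O)NCCCCCCCCCCCC(=O)NC(CCCCN)C(=O)NCCCCCCCCCCCC(=O)NC(CCCCN)C(=O)O` gives 75000 nM.

Compound 1 stands only at a limit in this assay, recorded as the limit of > 100000 nM in this assay, at which 1 of the 2 values shown sits. Within the data shown here, compound 2 returns a number, so the two values show no more than that compound 2 has a measured reading where compound 1 has none; no step between the two is counted. Compound 3 `NCCCCC(N)C(=O)NCCCCCCCCCCCC(=O)NC(CCCCN)C(=O)NCCCCCCCCCCCC(=O)NC(CCCCN)C(=O)O` is not yet measured. It differs from compound 1 by ((1,5-diaminopentyl)carbonyl)amino in place of hydrogen on a saturated chain carbon, ten or more bonds along the chain from a carbonyl carbon. Among the measured compounds shown here, with no measured step to lean on, the expectation from compound 1 to compound 3 is a small move, if any, toward a lower number, an at least 1.1-fold lower number from compound 1 to compound 3 (0.04 log units; that floor lies within the scatter), not beyond the usual scatter. Compound 3 is accordingly estimated at 90000 nM in this assay, with a range from 40000 nM to 200000 nM.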

Compound 3, half-maximal inhibitory concentration: > 400000 nM
Compound 3: only a limit was reported (the forecaster's own chance of this, stated with the estimate: 45%); middle value at least 4.4-fold (0.64 log units) from the limit.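

In this assay compound 3 gives > 400000 nM, a limit of the assay and not a number. Among these compounds, compound 1 also stands only at a limit, so no step between compound 1 and compound 3 can be read. The compounds shown leave open whether ((1,5-diaminopentyl)carbonyl)amino in place of hydrogen shifts the reading at all, and in which direction.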